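Morpholine Amide Replaces Primary Amide on the Ether Chain

This account rests on a few compounds, and the source may have more. Where it says the series, first, only, none or still open, it means among the compounds named here.

Going by the values given here, compound 3 `CC(C)[C@H]1C(O)=C(C2=NS(=O)(=O)c3c(OCCC(N)=O)cccc32)C(=O)N1Cc1ccccc1` is one of three compounds measured in an ADME assay on Huh-7 cells (Homo sapiens) for cytotoxicity, with a stated time of 72 h; a lower number here means that less compound is tolerated, a higher number that more compound is tolerated. For compound 3 the result is a limit, > 33000 nM. For compound 1 `CCOc1cccc2c1S(=O)(=O)N=C2C1=C(O)[C@H](C(C)C)N(Cc2ccccc2)C1=O` the result is likewise a limit, > 33000 nM. For compound 2 `CC(C)[C@H]1C(O)=C(C2=NS(=O)(=O)c3c(O)cccc32)C(=O)N1Cc1ccccc1` the result is also a limit, > 33000 nM. In short, (the limit of > 33000 nM in this assay, at which 3 of the 3 values shown sit), so compound 3 stands exactly where the other two stand, with no order among them to be read.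

The change now considered is (morpholin-4-yl)carbonyl in place of carbamoylmethyl on a saturated chain carbon bound to an oxygen on an aromatic ring, which gives compound 4 `CC(C)[C@H]1C(O)=C(C2=NS(=O)(=O)c3c(OCC(=O)N4CCOCC4)cccc32)C(=O)N1Cc1ccccc1`. The measured steps that touch the same oxygen on the aromatic ring are a step that the two limits leave unreadable from compound 1 to compound 2, a step that the two limits leave unreadable from compound 1 to compound 3 and a step that the two limits leave unreadable from compound 2 to compound 3. None of them has a readable size because the limit of > 33000 nM in this assay, at which 3 of the 3 values shown sit, fixes both ends of each. They therefore offer no direction for the present change, and nothing in the three values suggests a departure from the limit.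

The step from compound 3 to compound 4 is thus expected to be a step that the limit leaves unreadable from compound 3 to compound 4, most likely no step beyond the scatter. Compound 4 is estimated in this assay at 45000 nM, within 20000 nM to 120000 nM, with another limit the most probable outcome.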

Compound 4, half-maximal cytotoxic concentration: > 33000 nM
Compound 4: a limit, no number (the forecaster's own chance of this, stated with the estimate: 85%); the middle value lies beyond the limit too.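

No step from compound 1, compound 2 or compound 3 to compound 4 can be read, because both ends of each step are fixed at the same limit: the limit of > 33000 nM in this assay, at which 4 of the 4 values shown sit.

The compounds shown leave open whether any group on the oxygen on the aromatic ring would give a number in this assay rather than a limit.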